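The source may hold more compounds than are shown below. What is called first, only, known or untested is meant among the compounds shown, and "the series" means these compounds.

Measured in an ADME assay on MT4 cells (Homo sapiens) for cytotoxicity, read by MTT assay; on this read-out higher numbers stand for lower toxicity in this test and lower numbers for higher toxicity in this test:
compound 1 `Cc1ccc(N(C(=O)c2ccc([N+](=O)[O-])cc2)C(=S)OCCN2C(=O)c3ccccc3C2=O)cc1`: 58000 nM
compound 2 `Cc1ccc(N(C(=O)c2cc(F)ccc2F)C(=S)OCCN2C(=O)c3ccccc3C2=O)cc1`: 62000 nM
compound 3 `Cc1ccc(N(C(=O)c2cc(F)cc(F)c2)C(=S)OCCN2C(=O)c3ccccc3C2=O)cc1`: 54000 nM

Compound 3 stands level with the other two compounds: its number lies within the scatter of both, so no order can be read among them. The next compound is compound 4 `Cc1ccc(N(C(=O)c2ccc(Cl)c(Cl)c2)C(=S)OCCN2C(=O)c3ccccc3C2=O)cc1`, with 3,4-dichlorophenyl in place of 3,5-difluorophenyl on a carbonyl carbon. The measured steps that bear on this exchange all replace the group at that same carbonyl carbon: a 1.1-fold lower number from compound 1 to compound 3 (0.03 log units; within the scatter), a 1.1-fold lower number from compound 2 to compound 3 (0.06 log units; within the scatter) and a 1.1-fold higher number from compound 1 to compound 2 (0.03 log units; within the scatter). All three are small and within the scatter. Among the measured compounds shown here, none of the measured compounds carries chlorine, however, so this particular group remains untested. In this assay, no change beyond the scatter is therefore expected, and the estimated step is a 1.1-fold lower number from compound 3 to compound 4 (0.03 log units; within the scatter). For compound 4 the estimated value is 50000 nM, with an expected range from 25000 nM to 85000 nM.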

Compound 4, half-maximal cytotoxic concentration: 17000 nM
Estimate against measurement, compound 4: 2.9-fold (0.47 log units) above; the measured number lies below the stated range.
By their numbers in this assay, from the lowest: compound 4; then compounds 3, 1 and 2 (each within the scatter of the next).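

In this assay the group on the carbonyl carbon proves able to shift the number: the three earlier groups stood level within the scatter, whereas 3,4-dichlorophenyl gives a 3.2-fold lower number from compound 3 to compound 4 (0.50 log units; beyond the scatter) and a 3.6-fold lower number from compound 2 to compound 4 (0.56 log units; beyond the scatter) as well as a 3.4-fold lower number from compound 1 to compound 4 (0.53 log units; beyond the scatter). Each of these steps is modest, yet together they set compound 4 apart from all three others, and its lower number stands for higher toxicity in this test. Nothing at hand accounts for this shift.

The compounds shown do not separate the presence of chlorine from its placing, since 3,4-dichlorophenyl is the only chlorine-bearing group among them. On these data alone, it remains open whether a phenyl ring carrying a single chlorine, a bromine or a methoxy group would stay level with compounds 1, 2 and 3 or follow compound 4.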